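Swapping the cyclohexanol for a pyrrolidine-ethyl tail

The compounds below may be only part of what the source reports. "The series", "measured", "known", "first", "only" and "open" are said of these compounds alone.

Measured compounds:
- compound 1, `COc1cccc(OC)c1C(=O)Nc1c[nH]nc1C(=O)N[C@H]1CC[C@H](O)CC1`: 34000 nM
- compound 2, `CO[C@H]1CC[C@H](NC(=O)c2n[nH]cc2NC(=O)c2ccc(N3CCN(C)CC3)cc2)CC1`: 20000 nM
- compound 3, `CCc1ccccc1C(=O)Nc1c[nH]nc1C(=O)N[C@H]1CC[C@H](OC)CC1`: 3400 nM

All three compounds share a core and were tested in an ADME assay on MRC5 cells (Homo sapiens) for inhibition, with a stated time of 72 h; on this read-out higher numbers stand for an effect only at larger amounts of compound and lower numbers for an effect already at smaller amounts. On these numbers compound 1 gives the highest value. Compound 2 sits close by, and its value lies within the scatter of that of compound 1, so the two cannot be told apart. Compound 3 stands further off, with a value beyond the scatter and thus a clearly smaller number than compound 1.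

Compound 4, `COc1cccc(OC)c1C(=O)Nc1c[nH]nc1C(=O)NCCN1CCCC1`, has not yet been measured. It differs from compound 1 in one place: 2-(pyrrolidin-1-yl)ethyl in place of 4-hydroxycyclohexyl on an amide-type nitrogen. Among the compounds with values here, no measured pair shows this particular change, so the size of the step is uncertain. With compound 1 and compound 2 giving values at the high end of the range seen, and the new tail being no larger than the old one, the expectation is a step of a 1.7-fold lower number from compound 1 to compound 4 (0.23 log units; within the scatter), small and likely within the scatter, if anything towards a lower number. For compound 4 the estimated value in this assay is 20000 nM, with a range from 6000 nM to 60000 nM.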

Compound 4, half-maximal effective concentration: > 50000 nM
Compound 4: only a limit was reported; the forecaster's own chance of this, stated with the estimate: 15%; at least 2.5-fold (0.39 log units) between middle value and limit.
By their numbers in this assay, from the lowest: compound 3; then compounds 2 and 1 (each within the scatter of the next). At a limit, above all of these: compound 4.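

In this assay compound 4 gives > 50000 nM, which is a limit of the assay and not a number. Putting 2-(pyrrolidin-1-yl)ethyl in place of 4-hydroxycyclohexyl on an amide-type nitrogen gives an at least 1.4-fold higher number from compound 1 to compound 4 (0.16 log units; that floor lies within the scatter), the only change in one place among the compounds shown, and it shows that this tail brings no lower number at this position. Only this floor can be read, not the true size of the step: the limit of > 50000 nM in this assay, at which 1 of the 4 values shown sits.

Going by these compounds, what stays open is how far the value of compound 4 lies past the limit, and whether the nitrogen of the tail or the loss of the cyclohexane ring matters more. A morpholine at the end of the same ethyl chain, or a plain cyclohexyl on the same nitrogen, would help to separate these two parts of the change.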